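The source may hold more compounds than are shown below. What is called first, only, known or untested is meant among the compounds shown, and "the series" means these compounds.

Among the compounds with values here, in a physicochemical assay for solubility, measured as kinetic solubility, with a stated time of 1 h, at pH 7.4 (a higher number here means a more soluble compound, a lower number a less soluble compound), compound 1 `N#CCC(=O)NC1=NN(c2ccc(Cl)c(Cl)c2)CC1` gives 202000 nM and compound 2 `CC(=O)N[C@@H](C)C(=O)NC1=NN(c2ccc(Cl)c(Cl)c2)CC1` gives 58000 nM, the lower of the two numbers so far. Compound 3 `O=C1CCCC(C(=O)NC2=NN(c3ccc(Cl)c(Cl)c3)CC2)N1` differs from compound 2 only in the group on a carbonyl carbon: 6-oxopiperidin-2-yl in place of 1-acetamidoethyl on a carbonyl carbon. A group with no ring thus gives way to a six-membered non-aromatic ring. Within the data shown here, only one measured step bears on this, a 3.5-fold lower number from compound 1 to compound 2 (0.54 log units; beyond the scatter), a modest change at the same place. That single step involved a different pair of groups and offers no firm direction for the new change. No step beyond the scatter is therefore expected in this assay. The expected step is small: a 1.1-fold lower number from compound 2 to compound 3 (0.02 log units; within the scatter). For compound 3 the estimated value is 55000 nM, with an expected range from 20000 nM to 150000 nM.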

Compound 3, solubility: 416000 nM
The estimate for compound 3 lay 7.6-fold (0.88 log units) below the measured number, and the stated range ends below it.
By their numbers in this assay, from the lowest: compound 2; then compound 1; then compound 3.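

In this assay, the group on a carbonyl carbon can move the number in either direction: the earlier pair showed only a fall, whereas 6-oxopiperidin-2-yl in place of 1-acetamidoethyl gives a rise (a 7.2-fold higher number from compound 2 to compound 3 (0.86 log units; beyond the scatter)). The same ring also stands above cyanomethyl (a 2.1-fold higher number from compound 1 to compound 3 (0.31 log units; beyond the scatter)), so compound 3 holds the highest number of the three, with its steps to both others beyond the scatter. No evidence on the origin of this rise is available.

Within the data shown here, with only one ring-bearing compound, it remains open whether the rise belongs to the ring as such or to its carbonyl and nitrogen, which a piperidin-2-yl or cyclohexyl group on the same carbonyl carbon would help to separate. The compounds also leave open how an amine or a carboxylic acid would read at this place.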